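A Larger Aryl Group on the Shared Core

The source may report more compounds than this note shows. Statements on the series, on what has been measured and on what is new or still open speak of the compounds shown alone.

Values so far in a functional assay on HCC827 cells (Homo sapiens) for cytotoxicity, read by MTT assay, with a stated time of 72 h; a higher number here means a weaker inhibitor, a lower number a stronger inhibitor:
Compound 1 `CC(C)n1c(Nc2ccccc2)nc2cnc(Nc3ccc(N4CCN(C)CC4)cc3)nc21` gives 0.1 nM
Compound 2 `CN1CCN(c2ccc(Nc3ncc4nc(Nc5ccccc5)n(-c5ccccc5)c4n3)cc2)CC1` gives 1.7 nM
Compound 3 `Cc1cc(C)cc(-n2c(Nc3ccccc3)nc3cnc(Nc4ccc(N5CCN(C)CC5)cc4)nc32)c1` has not yet been measured

Compound 2 holds the higher of the two numbers, and its gap to compound 1 lies beyond the scatter. Compound 3 carries 3,5-dimethylphenyl in place of phenyl on an aromatic nitrogen and otherwise matches compound 2. Among the measured compounds shown here, only one measured change falls on this nitrogen, the large step of a 17-fold higher number from compound 1 to compound 2 (1.23 log units; beyond the scatter), and it went towards a higher number. For the measured compounds named here, no measured step shows what 3,5-dimethylphenyl does there, so the evidence is thin. In this assay a modest further rise, well short of that step, is expected. The expected change is a 2.4-fold higher number from compound 2 to compound 3 (0.37 log units; beyond the scatter) and remains only an estimate. For compound 3 the estimated value is 4 nM, with an expected range from 0.8 nM to 20 nM.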

Compound 3, half-maximal inhibitory concentration: 1 nM
Estimate against measurement, compound 3: 4.0-fold (0.60 log units) above; the measured number falls inside the stated range.
By their numbers in this assay, from the lowest: compound 1; then compounds 3 and 2 (each within the scatter of the next).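

In this assay, 3,5-dimethylphenyl on the aromatic nitrogen gives a 1.7-fold lower number from compound 2 to compound 3 (0.23 log units; within the scatter) and so cannot be told apart from phenyl, which shows that this substitution on the aryl ring leaves the number within the scatter. The replacement of isopropyl by this larger aryl group gives a 10-fold higher number from compound 1 to compound 3 (1.00 log units; beyond the scatter) and thus stands beyond the scatter, so both aryl groups shown on this nitrogen now sit on the higher side of isopropyl, with no compound here going against that. No measured evidence accounts for either result.

The compounds shown leave open whether a cyclopentyl or ethyl group on this nitrogen would stay close to isopropyl. They also leave open how the number would respond to an amine or a carboxylic acid on the aryl ring.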